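Swapping the amine's fluorophenyl for a 2-nitrophenyl

The source may hold more compounds than are shown below. What is called first, only, known or untested is meant among the compounds shown, and "the series" means these compounds.

Of the compounds shown here, three with one shared core have been measured in a functional assay, with a stated time of 6 min; on this read-out lower numbers stand for stronger inhibition and higher numbers for weaker inhibition. Compound 1 `Fc1cccc(NCn2nc(-c3ccc4c(c3)OCCO4)oc2=S)c1` gives 6620 nM, compound 2 `Fc1ccc(NCn2nc(-c3ccc4c(c3)OCCO4)oc2=S)cc1` gives 6480 nM and compound 3 `S=c1oc(-c2ccc3c(c2)OCCO3)nn1CNc1cccc(Cl)c1` gives 6220 nM. Compound 2 has the second highest of the three numbers, with a 1.0-fold lower number from compound 1 to compound 2 (0.01 log units; within the scatter) and a 1.0-fold lower number from compound 2 to compound 3 (0.02 log units; within the scatter), so none of the three can be told apart. Compound 4 `O=[N+]([O-])c1ccccc1NCn1nc(-c2ccc3c(c2)OCCO3)oc1=S` differs from compound 2 by 2-nitrophenyl in place of 4-fluorophenyl on an amine nitrogen. The steps from compound 1 to compound 2 and from compound 2 to compound 3 bear on this, as each also changed the group on that amine nitrogen, and both stayed within the scatter, as did a 1.1-fold lower number from compound 1 to compound 3 (0.03 log units; within the scatter). Among the compounds with values here, no step to a 2-nitrophenyl is known, so nothing beyond the scatter is expected. Compound 4 is therefore estimated at 6500 nM, between 3000 nM and 14000 nM, an expected step of a 1.0-fold higher number from compound 2 to compound 4 (0.00 log units; within the scatter).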

Compound 4, half-maximal inhibitory concentration: 10900 nM
Estimate against measurement, compound 4: 1.7-fold (0.22 log units) below; the range from low to high includes it.
By their numbers in this assay, from the lowest: compounds 3, 2, 1 and 4 (each within the scatter of the next).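

In this assay the 2-nitrophenyl, which brings hydrogen-bond acceptors that the 4-fluorophenyl lacks, gives a 1.7-fold higher number from compound 2 to compound 4 (0.23 log units; within the scatter) and a 1.8-fold higher number from compound 3 to compound 4 (0.24 log units; within the scatter) and a 1.6-fold higher number from compound 1 to compound 4 (0.22 log units; within the scatter) so compound 4 cannot be told apart from the other three. Across these four compounds, then, even this larger group on the amine nitrogen produces no step beyond the scatter. No measurement shown here accounts for the result. Going by these compounds, whether a carboxylic acid on the phenyl ring, or a longer chain in its place, would move the number beyond the scatter remains open.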